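Chloro for methoxy on the aryl of the shared core

A few compounds are considered here, and "the series" means these few. Any claim that something is new, unique, unknown or untested is made for them only; others in the source may bear on it.

Compound 2 `COc1ccc(C2=NN(c3nc(-c4ccc(C(F)(F)F)cc4)cs3)C(c3cccs3)C2)cc1` gives 8110 nM in a functional assay on WM 266-4 cells (Homo sapiens) for antiproliferative activity, read by MTT assay, with a stated time of 48 h (a lower number here means a stronger inhibitor, a higher number a weaker inhibitor), the lower of the two numbers recorded, compound 1 `COc1ccc(C2=NN(c3nc(-c4ccc(OC)cc4)cs3)C(c3cccs3)C2)cc1` giving 31600 nM in this assay. Compound 3 `FC(F)(F)c1ccc(-c2csc(N3N=C(c4ccc(Cl)cc4)CC3c3cccs3)n2)cc1` differs from compound 2 by chloro in place of methoxy on an aromatic carbon. Among the compounds with values here, no measured step matches this change; the one step recorded, a 3.9-fold lower number from compound 1 to compound 2 (0.59 log units; beyond the scatter), concerns the other aryl and removed a methoxy there. On that basis compound 3 is expected to show a modest, uncertain step of a 1.4-fold lower number from compound 2 to compound 3 (0.13 log units; within the scatter) in this assay. The estimate for compound 3 is 6000 nM, in the range 2000 nM to 20000 nM.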

Compound 3, half-maximal inhibitory concentration: 120 nM
Estimate against measurement, compound 3: 50-fold (1.70 log units) above, outside the stated range (below it).
By their numbers in this assay, from the lowest: compound 3; then compound 2; then compound 1.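

In this assay the change from 4-methoxyphenyl to 4-chlorophenyl, para to a large group, gives a 68-fold lower number from compound 2 to compound 3 (1.83 log units; beyond the scatter) and is a large step. The earlier step, a 3.9-fold lower number from compound 1 to compound 2 (0.59 log units; beyond the scatter), was modest and lay on the other aryl, so among these compounds this position shows the greater response. Nothing available explains why chloro has this effect here. As far as these compounds go, whether bromo, fluoro or an amine at this position would give a similar number remains open. So does whether chloro would give a step of this size with methoxy in place of trifluoromethyl on the other aryl.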